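Terminal hydroxy on the hexyl chain of compound 1

This account rests on a few compounds, and the source may have more. Where it says the series, first, only, none or still open, it means among the compounds named here.

Measured compounds:
- compound 1, `CCCCCCc1cn(C(c2ccccc2)c2cc3cc(Br)ccc3nc2OC)nn1`: 6.08%
- compound 2, `CCCCCCCCc1cn(C(c2ccccc2)c2cc3cc(Br)ccc3nc2OC)nn1`: 12.1%
- compound 3, `COc1nc2ccc(Br)cc2cc1C(c1ccccc1)n1cc(-c2ccccc2C(F)(F)F)nn1`: 11.4%

Of the compounds shown here, three sharing the core of compound 1 have been tested in an ADME assay on PANC-1 cells (Homo sapiens) for cytotoxicity, read by sulforhodamine B assay, with a stated time of 48 h, tested at 10 uM; on this read-out higher numbers stand for more inhibition at the one concentration tested (going by the name of the read-out) and lower numbers for less inhibition. Compound 1 sits at the low end of the three numbers, but the step of a number 6 percentage points higher from compound 1 to compound 2 (within the scatter) and the step of a number 5.3 percentage points higher from compound 1 to compound 3 (within the scatter) are both within the scatter, so the three numbers do not separate from one another. Compound 2 and compound 3 are likewise close, with a number 0.7 percentage points lower from compound 2 to compound 3 (within the scatter).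

Compound 4, `COc1nc2ccc(Br)cc2cc1C(c1ccccc1)n1cc(CCCCCO)nn1`, is not yet measured. It differs from compound 1 as follows: hydroxy in place of methyl on a saturated chain carbon, five bonds along the chain from an aromatic carbon.

For the measured compounds named here, no measured step changes the chain in this way. Going by the values given here, the steps that bear on it are those that alter the same aromatic carbon's substituent, a number 6 percentage points higher from compound 1 to compound 2 (within the scatter) and a number 5.3 percentage points higher from compound 1 to compound 3 (within the scatter), which lengthen the chain or replace it with 2-(trifluoromethyl)phenyl; neither moves beyond the scatter. On this basis compound 4 is expected to show no step beyond the scatter, a number 1.9 percentage points higher from compound 1 to compound 4 (within the scatter). Compound 4 is therefore estimated at 8%, with a range from 0% to 18%.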

Compound 4, a percentage reported as inhibition, at one concentration (the size of the read-out at that concentration, not a potency): 19.6%
Compound 4: middle estimate off by 11.6 percentage points, on the low side, and the stated range ends below it.
By their numbers in this assay, from the lowest: compounds 1, 3, 2 and 4 (each within the scatter of the next, the first and the last beyond it).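

In this assay, for the compounds shown here, hydroxy in place of methyl on a saturated chain carbon, five bonds along the chain from an aromatic carbon, gives the first step at this substituent that clears the scatter, a number 13.5 percentage points higher from compound 1 to compound 4 (beyond the scatter), which neither the longer octyl chain of compound 2 nor the 2-(trifluoromethyl)phenyl group of compound 3 had done. That separation holds only against compound 1, for the other two steps, a number 8.2 percentage points higher from compound 3 to compound 4 (within the scatter) and a number 7.5 percentage points higher from compound 2 to compound 4 (within the scatter), stay inside the scatter, so the hydroxy chain does not stand apart from the octyl or the 2-(trifluoromethyl)phenyl compound. Nothing in the data shown accounts for the step.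

The compounds shown leave open whether an amine or a carboxylic acid in place of the hydroxy would give a step of similar size, and whether a shorter chain such as 2-hydroxyethyl would keep it. They also leave open how the step would look at other concentrations, as this read-out gives the size of the effect at a single concentration and no potency.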